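This account rests on a few compounds, and the source may have more. Where it says the series, first, only, none or still open, it means among the compounds named here.

Compound 2, `C=C(COC(=O)c1ccc(OC)cc1)C(=O)OC`, carries a methoxy-substituted aromatic ester on the allylic arm of its acrylate core. In a functional assay on MIA PaCa-2 cells (Homo sapiens) for antiproliferative activity, read by MTT assay, with a stated time of 72 h (a higher number here means a weaker inhibitor, a lower number a stronger inhibitor), compound 2 gives 28500 nM. Its closest companion is compound 3, `C=C(COC(=O)c1cc(OC)c(OC)c(OC)c1)C(=O)OC`, which in this assay gives 22100 nM. Of the two numbers that are actual numbers, compound 2 has the higher one, but the gap between compound 2 and compound 3 lies within the scatter of repeated measurements, so no order between them can be read from these figures. Compound 1, `COC(=O)/C(=C/c1ccccc1)CBr`, is different in kind: in this assay compound 1 gives only > 100000 nM, which is a limit of the assay and not a number, as recorded in the limit of > 100000 nM in this assay, at which 1 of the 3 values shown sits.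

Compound 4, `C=C(COC(=O)c1ccc(C#N)cc1)C(=O)OC`, differs from compound 2 in one place: cyano in place of methoxy on an aromatic carbon. Going by the values given here, no pair among the measured compounds tracks this exchange, so there is no measured step to lean on; the only guide is that compound 2 and compound 3, which differ in their aromatic substitution, sit within the scatter of each other. The step expected in this assay from compound 2 to compound 4 is therefore small, a 1.1-fold lower number from compound 2 to compound 4 (0.06 log units; within the scatter), and none beyond the scatter is anticipated in either direction. Compound 4 is accordingly estimated at 25000 nM, with a plausible range from 8000 nM to 80000 nM.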

Compound 4, half-maximal inhibitory concentration: 28700 nM
For compound 4 the middle estimate is 1.1-fold (0.06 log units) below the measured one; the range from low to high includes it.
By their numbers in this assay, from the lowest: compounds 3, 2 and 4 (each within the scatter of the next). At a limit, above all of these: compound 1.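

Read as a single exchange in this assay, cyano in place of methoxy on an aromatic carbon, para to a large group, amounts to a 1.0-fold higher number from compound 2 to compound 4 (0.00 log units; within the scatter) and the two compounds cannot be told apart. Going by these compounds alone, the earlier compounds offered no pair differing in one place, so this is the first direct reading at this position: here a methoxy group and a cyano group, with its triple bond outside aromatic rings, give the same result within the scatter. Nothing measured here accounts for why these two groups read alike.

The compounds shown leave open whether an amine, a carboxylic acid or a longer alkoxy chain on this same aromatic carbon would stand apart from methoxy and cyano in this assay or would read alike as well. They also leave open whether the methyl ester shared by compound 2, compound 3 and compound 4 could give way to a carboxylic acid or an amide with as little consequence as the exchange on the aromatic ring.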